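This account rests on a few compounds, and the source may have more. Where it says the series, first, only, none or still open, it means among the compounds named here.

Series notes. Compound 1 `O=S(=O)(Nc1ccc(-c2nc3ccccc3o2)cc1)c1cccc(O)c1` carries a 3-hydroxyphenyl on the sulfonyl sulfur. In an assay on isolated protein for inhibition of malate dehydrogenase, mitochondrial (Sus scrofa), with stated times of 45 min and 30 min (a higher number here means a weaker inhibitor, a lower number a stronger inhibitor), compound 1 gives only a limit, > 63000 nM, and no number. Compound 2 `COc1ccc(S(=O)(=O)Nc2ccc3oc(-c4ccccc4)nc3c2)cc1` is a second analogue; in this assay compound 2 likewise gives only a limit, > 63000 nM. Among the measured compounds shown here, both measured values thus sit at the same limit (the limit of > 63000 nM in this assay, at which 2 of the 2 values shown sit), so compound 1 cannot be ranked against compound 2; it stands at the limit, not at a number, and no step between measured compounds is available.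

Compound 3 `O=S(=O)(Nc1ccc(-c2nc3ccccc3o2)cc1)c1ccc(F)cc1` is not yet measured. Its difference from compound 1: 4-fluorophenyl in place of 3-hydroxyphenyl on a sulfonyl sulfur. Given that both measured compounds rest at the limit (the limit of > 63000 nM in this assay, at which 2 of the 2 values shown sit), no step beyond the scatter is expected in this assay in either direction for compound 3, and a limit is again the most likely report. Compound 3 is estimated at 80000 nM, in the range 20000 nM to 300000 nM. That estimate corresponds to an expected step that the limit leaves unreadable from compound 1 to compound 3.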

Compound 3, half-maximal inhibitory concentration: > 63000 nM
Compound 3 ended at the assay's limit; the forecaster's own chance of this, stated with the estimate: 85%; the middle value lies beyond the limit too.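

Compound 3, like compound 1, rests at a limit in this assay, so the swap of 3-hydroxyphenyl for 4-fluorophenyl gives no readable step: the limit of > 63000 nM in this assay, at which 3 of the 3 values shown sit.

The compounds shown leave open which change to the shared core, if any, would bring a measurable inhibition value.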